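The source may hold more compounds than are shown below. What is called first, only, known or untested is meant among the compounds shown, and "the series" means these compounds.

Compound 1 `COc1nc(C)nc(/N=C/c2ccccc2)n1` — "not determined" (no result reported)
Compound 2 `COc1nc(C)nc(/N=C/c2cccc([N+](=O)[O-])c2)n1` — "not determined" (no result reported)
Compound 3 `COc1nc(C)nc(/N=C/c2ccc(Cl)cc2Cl)n1` — > 50 ug/mL

In an ADME assay on Vero cells (Chlorocebus sabaeus) for cytotoxicity, read by MTT assay, with a stated time of 72 h (a higher number here means a weaker inhibitor, a lower number a stronger inhibitor), compound 3 gives > 50 ug/mL, which is a limit of the assay rather than a number. Compound 1 has no result; for compound 1 the entry reads "not determined" (no result reported). Within the data shown here, compound 2 likewise has no single number, so it cannot be placed on any scale against the others; the only reading among the three is the limit of > 50 ug/mL in this assay, at which 1 of the 3 values shown sits. Compound 4 `COc1nc(C)nc(/N=C/c2cccc(Br)c2)n1` differs from compound 2 by bromo in place of nitro on an aromatic carbon. Among the measured compounds shown here, no measured step of this kind exists, and for this assay no shift beyond the usual scatter is expected in either direction. Compound 4 is expected to give about 60 ug/mL, estimated between 25 ug/mL and 200 ug/mL.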

Compound 4, half-maximal inhibitory concentration: > 50 ug/mL
Compound 4 was reported as a limit; the forecaster's own chance of this, stated with the estimate: 70%; the middle value is on the limit's open side.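

No step can be read from compound 2 to compound 4: compound 2 has no single number, and compound 4 is reported only as a limit. The compounds shown leave open the actual value of any of them in this assay, where the only reading is a limit: the limit of > 50 ug/mL in this assay, at which 2 of the 4 values shown sit.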